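Halogen swap on the urea aryl of a chloropyrazine urea

The source may report more compounds than this note shows. Statements on the series, on what has been measured and on what is new or still open speak of the compounds shown alone.

Measured so far:
compound 1, `Cc1cccc(NC(=O)Nc2cccc(CNc3nccnc3Cl)c2)c1` — 14600 nM
compound 2, `O=C(Nc1cccc(CNc2nccnc2Cl)c1)Nc1cccc(C(F)(F)F)c1` — 7290 nM

For the measured compounds named here, in a functional assay on MGC-803 cells (Homo sapiens) for antiproliferative activity, read by MTT assay, with a stated time of 48 h (on this read-out lower numbers stand for stronger inhibition and higher numbers for weaker inhibition), compound 1 gives 14600 nM, the highest of the two numbers recorded; its only neighbour is compound 2 with 7290 nM, and the step from one to the other is a 2.0-fold lower number from compound 1 to compound 2 (0.30 log units; within the scatter), so the two sit within the scatter of each other.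

Compound 3, `O=C(Nc1cccc(CNc2nccnc2Cl)c1)Nc1ccc(Cl)cc1Br`, has not been measured. It differs from compound 1 as follows: 2-bromo-4-chlorophenyl in place of 3-methylphenyl on an amide-type nitrogen.

Going by the values given here, only one measured step bears on this change, and only loosely: a 2.0-fold lower number from compound 1 to compound 2 (0.30 log units; within the scatter) shows that exchanging the methyl of compound 1 for a trifluoromethyl, a halogen-bearing group on the same aryl, moved the number by an amount inside the scatter. Compound 3 carries two halogens on that aryl instead, at different places, so the comparison is indirect. The expectation for compound 3 is therefore a step of a 1.7-fold lower number from compound 1 to compound 3 (0.23 log units; within the scatter) in this assay, small and uncertain in direction. The estimated value for compound 3 is 8500 nM, with a range from 3000 nM to 25000 nM.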

Compound 3, half-maximal inhibitory concentration: 7480 nM
The estimate for compound 3 lay 1.1-fold (0.06 log units) above the measured number; the measured number falls inside the stated range.
By their numbers in this assay, from the lowest: compounds 2, 3 and 1 (each within the scatter of the next).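

In this assay, putting 2-bromo-4-chlorophenyl in place of 3-methylphenyl on the amide-type nitrogen gives a 2.0-fold lower number from compound 1 to compound 3 (0.29 log units; within the scatter). The earlier pair covered only the exchange of methyl for trifluoromethyl on an otherwise unchanged aryl; this pair shows that the whole aryl can be exchanged, with a bromine and a chlorine in place of the methyl, and the number still stays within the scatter of compound 1. No measurement available here says what lies behind this result.

Going by these compounds, whether bromine alone or chlorine alone on this aryl would give a similar number remains open, as does the outcome with quite different groups at this place, such as an amine, a carboxylic acid or a longer alkyl chain. Also open is whether any change at this place can move the number beyond the scatter, for the three compounds shown each lie within the scatter of the next and so give no ranking among these aryl groups.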